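The source may hold more compounds than are shown below. What is called first, only, known or untested is meant among the compounds shown, and "the series" means these compounds.

Measured so far:
compound 1 `COc1cc(C)cc(-c2c(-c3ccnc(-c4ccc(C(C)=O)cc4)c3)cnn2CC#N)c1` — 101%
compound 2 `Cc1cc(O)cc(-c2nn(CC#N)cc2-c2ccnc(-c3ccc(N(C)C)cc3)c2)c1` — 108%

In a functional assay on OVCAR-4 cells (Homo sapiens) for cytotoxicity, read by sulforhodamine B assay, with a stated time of 48 h, tested at 0.01 uM (on this read-out higher numbers stand for a weaker effect at the one concentration tested and lower numbers for a stronger effect), compound 1 gives 101%, and compound 2 gives 108%. These two numbers lie within the usual scatter of each other, so neither compound stands apart at this concentration. Compound 3 `COc1cc(C)cc(-c2c(-c3ccnc(-c4ccc(N(C)C)cc4)c3)cnn2CC#N)c1` has not yet been tested. It differs from compound 1 in one place: dimethylamino in place of acetyl on an aromatic carbon. Compound 2 carries the same dimethylamino group and shows no effect at this concentration, so no step beyond the scatter is expected here. Compound 3 is therefore expected to give 103%, between 90% and 116%, a step of a number 2 percentage points higher from compound 1 to compound 3 (within the scatter).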

Compound 3, a percentage reported as activity, at one concentration (the size of the read-out at that concentration, not a potency): 77%
Beside the measured number, compound 3's estimate is 26 percentage points above it; measured number outside the range, below it.
By their numbers in this assay, from the lowest: compound 3; then compounds 1 and 2 (each within the scatter of the next).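

Going from 4-acetylphenyl to 4-(dimethylamino)phenyl gives a number 24 percentage points lower from compound 1 to compound 3 (beyond the scatter) in this assay, so the group on this aromatic carbon can change the read-out at the one concentration tested. This single step shows only that dimethylamino and acetyl differ here, not a trend across groups. Nothing measured here accounts for the step. From the compounds shown here alone, it remains open how a primary amine, a pyrrolidine ring or a carboxylic acid on this carbon would read. Going by these compounds, the effect of compound 3 at any other concentration also remains open.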